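The source may report more compounds than this note shows. Statements on the series, on what has been measured and on what is new or still open speak of the compounds shown alone.

Three related compounds have been measured in an assay on HEK293 cells for positive allosteric modulation of metabotropic glutamate receptor 3 (Rattus norvegicus), read by thallium flux, with a stated time of 2.5 min; on this read-out higher numbers stand for larger maximal responses and lower numbers for smaller maximal responses. Compound 1 `Cc1c(OCCCCOc2ccccc2C(=O)O)ccc(C(=O)CC(C)C)c1O` gives 28.1%. Compound 2 `COc1ccc(C(=O)O)cc1OCCCCOc1ccc(C(=O)CC(C)C)c(O)c1C` gives 100% in this assay, the highest of the three numbers. Compound 3 `Cc1c(OCCCCOc2cccc(C(=O)O)c2)ccc(C(=O)CC(C)C)c1O` gives 69.9% in this assay. Two single changes connect these three compounds: a number 41.8 percentage points higher from compound 1 to compound 3 (beyond the scatter), where 3-carboxyphenyl stands in place of 2-carboxyphenyl on an oxygen on a saturated carbon, and a number 30.1 percentage points lower from compound 2 to compound 3 (beyond the scatter), where hydrogen stands in place of methoxy on an aromatic carbon.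

Compound 4 `COc1ccc(C(=O)O)cc1OCCCCOc1ccc(C(C)=O)c(O)c1C` has not yet been measured in this assay. It differs from compound 2 in one place: hydrogen in place of isopropyl on a saturated chain carbon bound to a carbonyl carbon. Among the measured compounds shown here, neither measured step alters the group on the saturated chain carbon bound to a carbonyl carbon, so no measured step bears on this change directly. For the measured compounds named here, the two measured steps show only that single changes within this small set have moved the largest response by large amounts, in both directions. With no direct guide, the expected step is a number 25 percentage points lower from compound 2 to compound 4 (beyond the scatter), a moderate loss held with little confidence. Compound 4 is therefore estimated to give 75%, within a wide range from 40% to 100%.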

Compound 4, largest response reached (reported as percent of maximum), in percent of the reference or control that the assay uses: 34.8%
Compound 4: middle estimate off by 40.2 percentage points, on the high side; measured number below the stated range.
By their numbers in this assay, from the lowest: compounds 1 and 4 (each within the scatter of the next); then compound 3; then compound 2.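

Every earlier step changed the carboxyphenyl part of the molecule, whereas this change lies on a saturated chain carbon bound to a carbonyl carbon, and that site also proves sensitive. In this assay, hydrogen in place of isopropyl, which shortens isobutylcarbonyl to acetyl, gives a number 65.2 percentage points lower from compound 2 to compound 4 (beyond the scatter), so the response of compound 2 depends strongly on the 3 carbon atoms of the isopropyl, a group with no ring, no net charge and no hydrogen-bond donors or acceptors. No measurement among these compounds explains why the response falls with this change.

The compounds shown give only the two ends of this change, isopropyl and hydrogen, so they leave open whether a single methyl or an ethyl on the same carbon would keep part of the response, and whether a longer chain, a cyclohexyl ring or an amine would match or exceed isopropyl. As far as these compounds go, it also remains open whether the same loss would appear in a compound carrying hydrogen in place of the methoxy, since only the methoxy-bearing pair tests this change.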